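From chloro to methoxy on compound 3

The source may report more compounds than this note shows. Statements on the series, on what has been measured and on what is new or still open speak of the compounds shown alone.

Three related compounds frame this step. Compound 1 `CC(=O)N[C@H]1[C@H]([C@@H](O)[C@H](O)CNC(=O)c2ccc(Cl)cc2)O[C@@](OCc2ccccc2)(C(=O)O)C[C@@H]1O` carries the entry "not determined" (no result reported) in a physicochemical assay for lipophilicity, using the shake flask method, measured as octanol-water partition, at pH 7.4 (on this read-out lower numbers stand for lower lipophilicity and higher numbers for higher lipophilicity), and so offers no number for comparison. Compound 2 `CC(=O)N[C@H]1[C@H]([C@@H](O)[C@H](O)CNC(=O)c2ccc(Cl)cc2)O[C@@](OCc2c(F)c(F)c(F)c(F)c2F)(C(=O)O)C[C@@H]1O` gives -0.11 in this assay and compound 3 `O=C(CCl)N[C@H]1[C@H]([C@@H](O)[C@H](O)CNC(=O)c2ccc(Cl)cc2)O[C@@](OCc2cccc(F)c2F)(C(=O)O)C[C@@H]1O` gives 0.35 on the same scale. Compound 3 thus holds the higher of the two numbers, and its gap to compound 2 lies beyond the scatter. These two compounds differ in more than one place, so the gap cannot be tied to any single change.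

Compound 4 `COCC(=O)N[C@H]1[C@H]([C@@H](O)[C@H](O)CNC(=O)c2ccc(Cl)cc2)O[C@@](OCc2cccc(F)c2F)(C(=O)O)C[C@@H]1O` departs from compound 3 in one place (methoxy in place of chloro on a saturated chain carbon bound to a carbonyl carbon), with methoxy in place of chloro on a saturated chain carbon bound to a carbonyl carbon. Within the data shown here, no measured pair shows this exchange alone, so the expectation rests on the structural change itself and remains loosely anchored. A downward move in this assay is expected, of modest size and close to the edge of the scatter. The estimated change is a number 0.35 log units lower from compound 3 to compound 4 (beyond the scatter) on this reading. The expected value for compound 4 is 0 with -0.4 and 0.35 as the ends of its estimated range.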

Compound 4, distribution coefficient: 0.06
Compound 4: the middle estimate sits 0.06 log units below what was measured; low and high end bracket the measured number.
By their numbers in this assay, from the lowest: compounds 2, 4 and 3 (each within the scatter of the next, the first and the last beyond it).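

Among these compounds, the step of a number 0.29 log units lower from compound 3 to compound 4 (within the scatter) is the first reading of a change at a single place, so this assay can now be tied to one exchange rather than to compounds that differ in several places. At this saturated chain carbon bound to a carbonyl carbon, chloro, with 1 heavy atom and 0 hydrogen-bond acceptors, gives way to methoxy, with 2 heavy atoms and 1 hydrogen-bond acceptor, and this pair still cannot be told apart on this scale. No measured information on the origin of this result is available, so the reading stays a plain description of one pair.

As far as these compounds go, whether an amine, a carboxylic acid or a longer chain at this same place would give a step beyond the scatter remains open. Also open, from the compounds shown here alone, is whether methoxy in place of chloro would read the same with a different group elsewhere on the shared core, since this single pair offers no second instance of the exchange.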